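This account rests on a few compounds, and the source may have more. Where it says the series, first, only, none or still open, it means among the compounds named here.

The three measured compounds share one core, and none of them is strongly cytotoxic in an ADME assay on NIH3T3 cells (Mus musculus) for cytotoxicity, read by XTT assay, with a stated time of 24 h; on this read-out lower numbers stand for stronger inhibition and higher numbers for weaker inhibition. Compound 1 `CN(C)c1ccc(/C=N/NC(=O)CSc2nnnn2C)cc1` gives 316000 nM there, and compound 2 `Cn1nnnc1SCC(=O)N/N=C/c1cccc([N+](=O)[O-])c1` gives 2000000 nM. Compound 3 `Cn1nnnc1SCC(=O)N/N=C/c1ccccc1Cl` reaches only a limit of this assay, reported as > 10000000 nM. That is the limit of > 10000000 nM in this assay, at which 1 of the 3 values shown sits. Compound 4 `COc1ccccc1/C=N/NC(=O)CSc1nnnn1C` differs from compound 3 by methoxy in place of chloro on an aromatic carbon. For the measured compounds named here, no measured pair shows this change, so its size cannot be read from the data. Compound 3 stands at the limit, and no step beyond the scatter of this assay is expected, though a number just inside the measurable range is possible. Compound 4 is expected to give 7000000 nM, between 1500000 nM and 20000000 nM. For compound 4 this expectation amounts to an at least 1.4-fold lower number from compound 3 to compound 4 (0.15 log units; that floor lies within the scatter), and a report of only a limit again remains quite possible.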

Compound 4, half-maximal inhibitory concentration: 3160000 nM
Beside the measured number, compound 4's estimate is 2.2-fold (0.35 log units) above it; the measured number falls inside the stated range.
By their numbers in this assay, from the lowest: compound 1; then compounds 2 and 4 (each within the scatter of the next). At a limit, above all of these: compound 3.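

For the compounds shown here, with methoxy in place of chloro on this aromatic carbon, ortho to a large group, this assay shows an at least 3.1-fold lower number from compound 3 to compound 4 (0.50 log units; beyond the scatter) and so gives the first readable step at this position. This step is only a floor because compound 3 stands at a limit: the limit of > 10000000 nM in this assay, at which 1 of the 4 values shown sits.

On these data alone, whether an amine or a hydroxyl group on this carbon would give a lower or a higher number stays open. So does whether methoxy in place of chloro would give a step of similar size on another carbon of the same ring.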